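Swapping the Aryl Group on a Pyrimidine Urea Series

The source may hold more compounds than are shown below. What is called first, only, known or untested is meant among the compounds shown, and "the series" means these compounds.

Measured compounds:
Compound 1, `COc1cc(Br)ccc1Nc1cc(NC(=O)Nc2c(Cl)cccc2Cl)ncn1`, gives 43% in a functional assay on NCI-H226 cells (Homo sapiens) for inhibition, read by MTT assay, with a stated time of 48 h, tested at 10 uM; on this read-out lower numbers stand for less inhibition and higher numbers for more inhibition at the one concentration tested (going by the name of the read-out).
Compound 2, `COc1cc(NC(=O)Nc2cc(Nc3ccc(C)c(F)c3)ncn2)cc(OC)c1`, gives 39.7%.
Compound 3, `Cc1ccc(Nc2cc(NC(=O)Nc3c(Cl)cccc3Cl)ncn2)cc1C`, gives 41.3%.

All three compounds share the same core and differ only in the aryl group attached to the nitrogen on an aromatic ring and in the aryl group on the urea. Compound 2 sits close to both others: the gap between it and compound 3, and between it and compound 1, falls inside the usual scatter of repeated measurements, so no order among the three can be read from these numbers.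

Compound 4, `COc1cc(NC(=O)Nc2cc(Nc3ccc(OC)c(I)c3)ncn2)cc(OC)c1`, differs from compound 2 in one place: 3-iodo-4-methoxyphenyl in place of 3-fluoro-4-methylphenyl on a nitrogen on an aromatic ring.

Among the measured compounds shown here, only one measured step bears on this change. It exchanges the aryl group on the same nitrogen and gives a number 1.7 percentage points lower from compound 1 to compound 3 (within the scatter), a step within the scatter. With a single such step to go on, and that step flat, the expectation is that exchanging the aryl group at this position again leaves the number essentially unchanged, with the step of a number 0.3 percentage points higher from compound 2 to compound 4 (within the scatter) expected to stay within the scatter.

Compound 4 is therefore estimated at 40%, with a range from 28% to 52%.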

Compound 4, a percentage reported as inhibition, at one concentration (the size of the read-out at that concentration, not a potency): 40.1%
Estimate against measurement, compound 4: 0.1 percentage points below, within the range that was stated.
By their numbers in this assay, from the lowest: compounds 2, 4, 3 and 1 (each within the scatter of the next).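

The step of a number 0.4 percentage points higher from compound 2 to compound 4 (within the scatter) shows that the flat result at this position is not confined to one urea partner: compounds 2 and 4 carry a different aryl group on the urea from compounds 1 and 3, yet exchanging the aryl group on the nitrogen again stays within the scatter in this assay, as did a number 1.7 percentage points lower from compound 1 to compound 3 (within the scatter). The change is also larger in kind than the earlier one, since 3-iodo-4-methoxyphenyl brings in iodine, oxygen and a hydrogen-bond acceptor in place of the fluorine and methyl of 3-fluoro-4-methylphenyl, and still the number does not move beyond the scatter. Nothing measured here explains why this exchange leaves the number flat.

The two substituents on this ring change together, so the compounds shown cannot separate the part played by each, and no pair among them differs only in the aryl group on the urea. Going by these compounds, all the groups on this nitrogen are substituted phenyl rings, so it remains open whether a non-aromatic group, or a phenyl ring bearing a carboxylic acid or an amine, would shift the number.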